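The source may report more compounds than this note shows. Statements on the series, on what has been measured and on what is new or still open speak of the compounds shown alone.

Compound 1 `COc1cccc2c1CCC2c1ncc[nH]1` carries a methoxy on an aromatic carbon of the shared core. In a functional assay on CHO cells for agonist activity at Alpha-1B adrenergic receptor (Homo sapiens), read by FLIPR and calcium flux (a higher number here means that more compound is needed for the effect, a lower number that less compound is needed), compound 1 gives only a limit of the assay, > 10000 nM. Compound 2 `Cn1cc(-c2cccc3c2CCC3c2ncc[nH]2)cn1` has 1-methyl-1H-pyrazol-4-yl in place of methoxy on an aromatic carbon. In this assay compound 2 also gives only a limit, > 10000 nM. The step that the two limits leave unreadable from compound 1 to compound 2 is not readable, and the limit of > 10000 nM in this assay, at which 2 of the 2 values shown sit, records that both values shown sit at that limit. For the measured compounds named here, compound 2 thus stands as a limit only, with no number of its own, and no other measured compound supplies one. Compound 3 `c1cc(-c2ncco2)c2c(c1)C(c1ncc[nH]1)CC2` differs from compound 2 by 1,3-oxazol-2-yl in place of 1-methyl-1H-pyrazol-4-yl on an aromatic carbon. Going by the values given here, no measured step bears on this change, so neither a direction nor a size beyond the scatter can be read from the data; the only guidance is that both ends of the single measured step were limits. The expected step in this assay is a step that the limit leaves unreadable from compound 2 to compound 3. Compound 3 is therefore expected at 15000 nM, in a range from 4000 nM to 60000 nM, most probably reported again as a limit rather than a number.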

Compound 3, half-maximal effective concentration: > 10000 nM
Compound 3: a limit, no number (the forecaster's own chance of this, stated with the estimate: 80%); the middle value does not contradict the limit.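

In this assay compound 3 also gives only a limit, > 10000 nM. No step among compound 1, compound 2 and compound 3 can therefore be read, as every value shown is a limit: the limit of > 10000 nM in this assay, at which 3 of the 3 values shown sit.

The compounds shown leave open how these three rank and whether any group on this aromatic carbon gives a number in this assay.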